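This account rests on a few compounds, and the source may have more. Where it says the series, first, only, none or still open, it means among the compounds named here.

Measured so far:
Compound 1 `O=c1[nH]cnc2c1c(-c1ccoc1)cn2[C@@H]1O[C@H](CO)[C@@H](O)[C@H]1O`: in a functional assay on CEM-DNR-bulk cells (Homo sapiens), read by MTT assay, with a stated time of 72 h (a higher number here means a weaker inhibitor, a lower number a stronger inhibitor), compound 1 reaches only the limit > 20000 nM.
Compound 2 `O=c1[nH]cnc2c1c(-c1ccco1)cn2[C@@H]1O[C@H](CO)[C@@H](O)[C@H]1O`: in this assay compound 2 reaches only the limit > 20000 nM.
Compound 3 `COc1nc(N)nc2c1c(-c1ccoc1)cn2[C@@H]1O[C@H](CO)[C@@H](O)[C@H]1O`: in this assay compound 3 reaches only the limit > 20000 nM.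

Each of these three values is a limit of this assay and not a number, and the limit of > 20000 nM in this assay, at which 3 of the 3 values shown sit, tells where all of them sit. Compound 2 arises from compound 1 by furan-2-yl in place of furan-3-yl on an aromatic carbon, and that change gives a step that the two limits leave unreadable from compound 1 to compound 2. Compound 4 `COc1nc(N)nc2c1c(-c1ccco1)cn2[C@@H]1O[C@H](CO)[C@@H](O)[C@H]1O` has not yet been measured; it arises from compound 3 by furan-2-yl in place of furan-3-yl on an aromatic carbon, the same change at the same place. The difference between the core of compound 1 and the core of compound 3 is not broken down here. Compound 3 gives only the limit > 20000 nM in this assay. Compound 4 is expected to make the step that the limit leaves unreadable from compound 3 to compound 4, an expectation resting on that limit for compound 3 and on a step that the two limits leave unreadable from compound 1 to compound 2, which the limits leave unreadable. The estimate for compound 4 in this assay is 30000 nM, between 15000 nM and 100000 nM.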

Compound 4, half-maximal inhibitory concentration: > 20000 nM
Compound 4: no number, only a limit; the forecaster's own chance of this, stated with the estimate: 85%; the middle value is on the limit's open side.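

Compound 3 and compound 4 both stay at a limit, so the step between them cannot be read: the limit of > 20000 nM in this assay, at which 4 of the 4 values shown sit.

The compounds shown leave open how strong any of the four is in this assay and whether furan-2-yl and furan-3-yl differ there at all.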